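Removing a 4-(methoxycarbonyl)benzyl Group from Two Cores

The source may report more compounds than this note shows. Statements on the series, on what has been measured and on what is new or still open speak of the compounds shown alone.

Two related cores are compared here; the difference between them is not broken down here. Compound 1 `COC(=O)c1ccc(CN(CCCc2c(N)nc(N)nc2O)c2cc(F)cc(F)c2[N+](=O)[O-])cc1` was tested in a functional assay on CCRF-CEM cells (Homo sapiens) for cytotoxicity, in the absence of a further agent; on this read-out lower numbers stand for stronger inhibition and higher numbers for weaker inhibition. For compound 1 the result is a limit of the assay, > 100000 nM. Compound 3 `Nc1nc(N)c(CCCNc2cc(F)cc(F)c2[N+](=O)[O-])c(O)n1` carries the change (hydrogen in place of 4-(methoxycarbonyl)benzyl on a nitrogen on an aromatic ring), and in this assay compound 3 gives 97000 nM. The step of an at least 1.0-fold lower number from compound 1 to compound 3 (0.01 log units; that floor lies within the scatter) cannot be read as more than a floor, because compound 1 sits at the limit of > 100000 nM in this assay, at which 1 of the 3 values shown sits.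

Compound 2 `COC(=O)c1ccc(CN(CCCc2c(N)nc(N)nc2O)c2cc(F)c([N+](=O)[O-])cc2[N+](=O)[O-])cc1` belongs to the second core, and in this assay compound 2 gives 4300 nM. Among the compounds with values here, compound 4 `Nc1nc(N)c(CCCNc2cc(F)c([N+](=O)[O-])cc2[N+](=O)[O-])c(O)n1` is its unmeasured partner and carries hydrogen in place of 4-(methoxycarbonyl)benzyl on a nitrogen on an aromatic ring, the same change as the one from compound 1 to compound 3. Beside that earlier step, the step from compound 2 to compound 4 is expected to be a 1.9-fold higher number from compound 2 to compound 4 (0.27 log units; within the scatter). This expectation rests on compound 3, whose step an at least 1.0-fold lower number from compound 1 to compound 3 (0.01 log units; that floor lies within the scatter) stayed within the scatter. For compound 4 the estimated value in this assay is 8000 nM, with a range from 2000 nM to 40000 nM.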

Compound 4, half-maximal inhibitory concentration: 1000 nM
Beside the measured number, compound 4's estimate is 8.0-fold (0.90 log units) above it, and the stated range ends above it.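

On the core of compound 2, replacing the 4-(methoxycarbonyl)benzyl group with hydrogen on the nitrogen gives a 4.3-fold lower number from compound 2 to compound 4 (0.63 log units; beyond the scatter) in this assay, so on this core the group is not needed for the activity seen in these cells. The value of compound 1, > 100000 nM, is a limit of the assay and not a number. The two pairs therefore show the change on both cores but give no measure of how well its effect carries from one core to the other, and two pairs could not establish a rule for the series in any case: the same change on two cores in this assay, an at least 1.0-fold lower number (0.01 log units; that floor lies within the scatter) from compound 1 to compound 3 and a 4.3-fold lower number (0.63 log units; beyond the scatter) from compound 2 to compound 4; the limit leaves it open whether they differ.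

On these data alone, only hydrogen and 4-(methoxycarbonyl)benzyl appear on this nitrogen, so it stays open whether a plain benzyl group, a methyl group or a benzyl group carrying a carboxylic acid would behave more like compound 2 or compound 4. As far as these compounds go, how the change behaves on a core with a longer chain also stays open.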